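Adding a pyrrolidine-bearing tail to compound 2

The source may report more compounds than this note shows. Statements on the series, on what has been measured and on what is new or still open speak of the compounds shown alone.

Of the compounds shown here, three sharing one core have been tested in a functional assay on PC-3 cells (Homo sapiens) for antiproliferative activity, read by MTT assay, with a stated time of 72 h; a lower number here means a stronger inhibitor, a higher number a weaker inhibitor. Compound 1 `C=CC(=O)Nc1cc2c(N3CCc4ccccc43)ncnc2cc1OC` gives 5940 nM. Compound 2 `C=CC(=O)Nc1cc2c(N3CCc4ccccc43)ncnc2cc1O[C@@H]1CCOC1`, which carries an oxolan-3-yl in place of the methyl on the aromatic oxygen, gives 2710 nM, a change described by a 2.2-fold lower number from compound 1 to compound 2 (0.34 log units; beyond the scatter). Compound 3 `COc1cc2ncnc(N3CCc4ccccc43)c2cc1NC(=O)/C=C/CN1CCCCC1`, which instead extends the vinyl to a 3-(piperidin-1-yl)prop-1-en-1-yl, gives 4180 nM; the step of a 1.4-fold lower number from compound 1 to compound 3 (0.15 log units; within the scatter) is within the scatter. Among the three, compound 2 lies beyond the scatter below compound 1, while compound 3 sits within the scatter of compound 2.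

The next compound, compound 4 `O=C(/C=C/CN1CCCC1)Nc1cc2c(N3CCc4ccccc43)ncnc2cc1O[C@@H]1CCOC1`, keeps the oxolan-3-yl of compound 2 and alters the amide side: 3-(pyrrolidin-1-yl)prop-1-en-1-yl in place of vinyl on a carbonyl carbon. Among the measured compounds shown here, the one measured step that resembles this change is the extension of the same vinyl in compound 1 to give compound 3, and that step, a 1.4-fold lower number from compound 1 to compound 3 (0.15 log units; within the scatter), did not move beyond the scatter. The ring entering here is the five-membered relative of the piperidine in compound 3, so the expectation for compound 4 in this assay is a step of about a 1.3-fold lower number from compound 2 to compound 4 (0.11 log units; within the scatter), which would be no change beyond the scatter. Compound 4 is therefore estimated at 2100 nM, with a likely range from 900 nM to 4800 nM.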

Compound 4, half-maximal inhibitory concentration: 1510 nM
Estimate against measurement, compound 4: 1.4-fold (0.14 log units) above; the range from low to high includes it.
By their numbers in this assay, from the lowest: compounds 4, 2, 3 and 1 (each within the scatter of the next, the first and the last beyond it).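

In this assay, the step of a 1.8-fold lower number from compound 2 to compound 4 (0.25 log units; within the scatter) stays small, so the longer tail on the carbonyl carbon is tolerated when the aromatic oxygen carries oxolan-3-yl and not only methyl. The step of a 1.4-fold lower number from compound 1 to compound 3 (0.15 log units; within the scatter) is also small, so there are now two pairs in which replacing vinyl with a tail that ends in a saturated nitrogen ring leaves the number within the usual scatter, one with a pyrrolidine and one with a piperidine. Nothing measured here explains why these tails make so little difference to the number.

The compounds shown leave open whether the size of the ring matters, since pyrrolidine and piperidine are never compared on the same oxygen group, and a piperidine tail paired with oxolan-3-yl would settle that point. They also leave open whether the ring itself is needed at all, which a dimethylamino group or a morpholine at the end of the same chain could test.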